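Tetrachlorophthalimides: from pyrimidin-2-yl to pyridin-2-yl

A few compounds are considered here, and "the series" means these few. Any claim that something is new, unique, unknown or untested is made for them only; others in the source may bear on it.

Of the compounds shown here, two of a shared core have been measured in a functional assay on the whole organism (serum, strain Swiss albino) with Rattus norvegicus as the target, read by spectrophotometry, with a stated time of 14 days, at a dose of 10 mg/kg by the oral route; a higher number here means more inhibition at the dose given (going by the name of the read-out), a lower number less inhibition. Compound 1 `O=C1c2c(Cl)c(Cl)c(Cl)c(Cl)c2C(=O)N1Cc1ccccn1` gives 47%. Compound 2 `O=C1c2c(Cl)c(Cl)c(Cl)c(Cl)c2C(=O)N1c1ncccn1` gives 3%, the lowest of the two numbers, and the nearest number is that of compound 1, which stands a number 44 percentage points lower from compound 1 to compound 2 (beyond the scatter) apart. Among the compounds with values here, the single measured step thus replaced (pyridin-2-yl)methyl with pyrimidin-2-yl and cost a number 44 percentage points lower from compound 1 to compound 2 (beyond the scatter).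

Compound 3 `O=C1c2c(Cl)c(Cl)c(Cl)c(Cl)c2C(=O)N1c1ccccn1` has not yet been measured in this assay. Compared with compound 2, the change is pyridin-2-yl in place of pyrimidin-2-yl on an amide-type nitrogen in a ring. Within the data shown here, no measured step makes exactly this exchange: the step from compound 1 to compound 2 altered both the ring and the link to the amide-type nitrogen, so it bears on the present step only in part. Among the measured compounds shown here, the ring of compound 3 is the one found in compound 1, but the direct attachment is that of compound 2, so an intermediate number is expected, with a rise of a number 22 percentage points higher from compound 2 to compound 3 (beyond the scatter) from compound 2 as the estimate. Compound 3 is therefore expected to give about 25%, within a range from 5% to 48%.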

Compound 3, a percentage reported as inhibition, in the whole organism at one dose (the size of the read-out at that dose, not a potency): 9%
Compound 3: the middle estimate sits 16 percentage points above what was measured; the range from low to high includes it.
By their numbers in this assay, from the lowest: compounds 2 and 3 (each within the scatter of the next); then compound 1.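

In this assay, the exchange of pyrimidin-2-yl for pyridin-2-yl on the amide-type nitrogen in a ring gives a number 6 percentage points higher from compound 2 to compound 3 (within the scatter), so the two directly attached rings cannot be told apart at this position. With the pyridin-2-yl ring kept, removing the link that (pyridin-2-yl)methyl places between that ring and the nitrogen gives a number 38 percentage points lower from compound 1 to compound 3 (beyond the scatter), a large step that involves only the link. The earlier step from compound 1 to compound 2 changed the ring and the link together, whereas the three compounds now separate the two changes and tie the large difference to the link, with compound 1 the only one that carries it and none of the three going against this reading.

Nothing available here gives a reason for this difference. Open questions are whether (pyrimidin-2-yl)methyl would stand with compound 1 and whether a longer chain between the nitrogen and the pyridin-2-yl ring, or an amine or a carboxylic acid on that ring, would raise or lower the number in this assay.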